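The source may hold more compounds than are shown below. What is called first, only, known or untested is meant among the compounds shown, and "the series" means these compounds.

In a functional assay on HL-60 cells (Homo sapiens) for cytotoxicity, read by MTT assay (on this read-out higher numbers stand for weaker inhibition and lower numbers for stronger inhibition), compound 1 `CC(NS(=O)(=O)c1ccc(F)cc1)C1=CC(=O)c2c(O)ccc(O)c2C1=O` gives 90 nM and compound 2 `CC(NS(=O)(=O)c1ccc(Br)cc1)C1=CC(=O)c2c(O)ccc(O)c2C1=O` gives 100 nM on the same shared core. Going by the values given here, the two numbers lie within the scatter of each other, so compound 2 stands level with compound 1, the only other measured compound. Compound 3 `CC(NS(=O)(=O)c1cccc(Br)c1)C1=CC(=O)c2c(O)ccc(O)c2C1=O` holds the same atoms as compound 2, joined differently: 3-bromophenyl in place of 4-bromophenyl on a sulfonyl sulfur. Among the compounds with values here, the only measured step is bromo in place of fluoro on an aromatic carbon. Within the data shown here, with a 1.1-fold higher number from compound 1 to compound 2 (0.05 log units; within the scatter) as the sole guide, no step beyond the scatter is expected in this assay, although no measured pair tests the 3-bromophenyl group directly. The estimated step is no change at the digits printed from compound 2 to compound 3 (within the scatter) for now. For compound 3 the estimated value is 100 nM with an expected range from 40 nM to 250 nM.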

Compound 3, half-maximal inhibitory concentration: 160 nM
Compound 3: middle estimate off by 1.6-fold (0.20 log units), on the low side; the measured number falls inside the stated range.
By their numbers in this assay, from the lowest: compounds 1, 2 and 3 (each within the scatter of the next).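

The sulfonyl sulfur tolerates a shift of the bromine on its phenyl ring: in this assay placing 3-bromophenyl in place of 4-bromophenyl gives a 1.6-fold higher number from compound 2 to compound 3 (0.20 log units; within the scatter) and so stays inside the usual variation. The comparison with the fluorinated compound adds that 3-bromophenyl in place of 4-fluorophenyl, a change of both halogen and its printed position, gives a 1.8-fold higher number from compound 1 to compound 3 (0.25 log units; within the scatter) and also shows no step beyond the scatter. No measurement here offers an explanation for these small differences.

The compounds shown leave open whether 3-fluorophenyl would also remain level with these three in this assay and whether the same holds for a phenyl ring carrying an amine or a carboxylic acid. They also leave open how a longer chain in place of the aromatic ring on the sulfonyl sulfur would read.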